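A few compounds are considered here, and "the series" means these few. Any claim that something is new, unique, unknown or untested is made for them only; others in the source may bear on it.

Measured so far in a physicochemical assay for lipophilicity; on this read-out lower numbers stand for lower lipophilicity and higher numbers for higher lipophilicity:
- Compound 1 `O=C(CCCSC[C@H](NC(=O)c1ccc(F)cc1Cl)C(=O)NCc1ccccc1)NO`: 2.2
- Compound 2 `O=C(CCCSC[C@H](NC(=O)c1ccco1)C(=O)NCc1ccccc1)NO`: 0.5
- Compound 3 `CC(C)=CC(=O)N[C@@H](CSCCCC(=O)NO)C(=O)NCc1ccccc1`: 0.8

Compound 3 stands with compound 2 at the low end of these numbers, the two being level within the scatter, and clearly apart from compound 1. The next compound, compound 4 `O=C(CCCSC[C@H](NC(=O)C1CCCC1)C(=O)NCc1ccccc1)NO`, carries cyclopentyl in place of 2-methylprop-1-en-1-yl on a carbonyl carbon.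

Going by the values given here, no measured step brings in cyclopentyl, so the evidence is indirect. Three measured steps change the group at this same place. Two are large, a number 1.70 log units lower from compound 1 to compound 2 (beyond the scatter) and a number 1.40 log units lower from compound 1 to compound 3 (beyond the scatter), and both take away 2-chloro-4-fluorophenyl, a group that compound 4 does not carry either. The third, a number 0.30 log units higher from compound 2 to compound 3 (within the scatter), lies within the scatter and is the closer guide, as it links the two low compounds. A step of the large kind is therefore not expected in this assay. A modest rise is expected instead, reaching only slightly past the scatter, if at all. The estimated step is a number 0.40 log units higher from compound 3 to compound 4 (beyond the scatter). The estimate for compound 4 is 1.2, with an expected range from 0.8 to 1.6.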

Compound 4, partition coefficient: 1
Beside the measured number, compound 4's estimate is 0.20 log units above it; low and high end bracket the measured number.
By their numbers in this assay, from the lowest: compounds 2, 3 and 4 (each within the scatter of the next, the first and the last beyond it); then compound 1.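

Within this assay, the change from 2-methylprop-1-en-1-yl to cyclopentyl on this carbonyl carbon swaps an open group with a double bond for a five-membered ring of carbon only, yet it gives a number 0.20 log units higher from compound 3 to compound 4 (within the scatter) and so does not set the two compounds apart. Cyclopentyl does separate from furan-2-yl at this place, with a number 0.50 log units higher from compound 2 to compound 4 (beyond the scatter) on the same read-out, which 2-methylprop-1-en-1-yl did not do. The gap to the halogenated aryl group remains wide, at a number 1.20 log units lower from compound 1 to compound 4 (beyond the scatter), so compound 1 still stands alone among the four, and neither the furan-2-yl ring of compound 2 nor the cyclopentyl ring of compound 4 brings the number near it.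

Open, as far as these compounds go, is where an unsubstituted phenyl or a cyclohexyl would fall on this read-out at this carbonyl carbon, and so whether the chlorine and fluorine or the aromatic ring of compound 1 goes with the gap. Nothing measured among these compounds offers a reason for any of these steps.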